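Acetyl in place of cyclopropyloxy: compound 2 to compound 4

The source may report more compounds than this note shows. Statements on the series, on what has been measured and on what is new or still open speak of the compounds shown alone.

Measured so far:
compound 1 `Cc1cccc(C)c1OC(C)C1=NCCN1`: 27.5 nM
compound 2 `CC(Oc1ccccc1OC1CC1)C1=NCCN1`: 47.9 nM
compound 3 `C=CCc1cccc(CC=C)c1OC(C)C1=NCCN1`: 56.2 nM

In a functional assay on CHO cells for agonist activity at Alpha-2C adrenergic receptor (Homo sapiens) (on this read-out lower numbers stand for an effect already at smaller amounts and higher numbers for an effect only at larger amounts of compound), compound 1 gives 27.5 nM. Compound 2 gives 47.9 nM and compound 3 gives 56.2 nM. Compound 2 stands second highest of the three numbers, but its nearest neighbour, compound 3, and its furthest, compound 1, both lie within the usual scatter of it, so the three cannot be ordered; the shared core tolerates each of the aromatic substitution patterns tried so far with much the same outcome.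

Compound 4 `CC(=O)c1ccccc1OC(C)C1=NCCN1` is not yet measured. Compared with compound 2 the change is acetyl in place of cyclopropyloxy on an aromatic carbon. For the measured compounds named here, no step between two measured compounds is available to rest a prediction on, so the expectation draws only on the flat picture above. The step from compound 2 to compound 4 is expected to stay within the scatter, or at most a small drift in either direction. Compound 4 is therefore estimated at about 50 nM, with a range from 15 nM to 170 nM. This estimate means an expected step of a 1.0-fold higher number from compound 2 to compound 4 (0.02 log units; within the scatter).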

Compound 4, half-maximal effective concentration: 200 nM
For compound 4 the middle estimate is 4.0-fold (0.60 log units) below the measured one; measured number outside the range, above it.
By their numbers in this assay, from the lowest: compounds 1, 2 and 3 (each within the scatter of the next, the first and the last beyond it); then compound 4.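

In this assay, for the compounds shown here, acetyl in place of cyclopropyloxy on an aromatic carbon gives a 4.2-fold higher number from compound 2 to compound 4 (0.62 log units; beyond the scatter), the one step that can be read and one that lies beyond the scatter. This place, on a six-membered aromatic ring of carbon only and ortho to a group of 8 heavy atoms, therefore does not take every group alike, even though both groups count the same hydrogen-bond donors and acceptors and neither carries a net charge. No measurement at hand speaks to the cause of this step.

The compounds shown leave open whether the higher number goes with the loss of the three-membered ring or with the entry of the carbonyl. Methoxy, isopropyl or a primary amide in the same place would help to separate these two readings.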